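Methoxy on the aniline ring of two aminothiazoles

The compounds below may be only part of what the source reports. "The series", "measured", "known", "first", "only" and "open" are said of these compounds alone.

Measured so far:
compound 1 `c1ccc(Nc2nc(-n3cnc4ccccc43)cs2)cc1` > 100000 nM
compound 2 `Cc1nccn1-c1csc(Nc2ccccc2)n1` 32500 nM
compound 3 `COc1ccc(Nc2nc(-n3cnc4ccccc43)cs2)cc1` > 100000 nM

In a functional assay on RKO cells (Homo sapiens) for cytotoxicity, read by resazurin assay, with a stated time of 72 h (a higher number here means a weaker inhibitor, a lower number a stronger inhibitor), compound 1 gives > 100000 nM, which is a limit of the assay and not a number. Compound 3 likewise gives > 100000 nM in this assay, again a limit. Compound 2 is the only one of the three with a number in this assay, 32500 nM. How the core of compound 2 differs from the core of compound 1 is not broken down here.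

The change from compound 1 to compound 3 is methoxy in place of hydrogen on an aromatic carbon. Its step, a step that the two limits leave unreadable from compound 1 to compound 3, cannot be read, since both values sit at the limit of > 100000 nM in this assay, at which 2 of the 3 values shown sit.

Compound 4 `COc1cccc(Nc2nc(-n3ccnc3C)cs2)c1` has not yet been measured. Within the data shown here, its change from compound 2 is methoxy in place of hydrogen on an aromatic carbon, the same kind of change as the one from compound 1 to compound 3, but here the methoxy stands meta to a large group rather than para to it. Among the measured compounds shown here, with the earlier step unreadable, the only anchor is the value of compound 2, 32500 nM, so the step of a 1.1-fold higher number from compound 2 to compound 4 (0.03 log units; within the scatter) is expected to be small. Compound 4 is therefore estimated at 35000 nM, between 12000 nM and 100000 nM.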

Compound 4, half-maximal inhibitory concentration: 22500 nM
Compound 4: the middle estimate sits 1.6-fold (0.19 log units) above what was measured; measured number inside the range.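

In this assay, methoxy in place of hydrogen on an aromatic carbon, here meta to a large group, gives a 1.4-fold lower number from compound 2 to compound 4 (0.16 log units; within the scatter), so on the core of compound 2 the two values lie within the usual scatter of each other. Among these compounds, on the core of compound 1 the step to compound 3, where the methoxy does not stand meta to a large group, cannot be read, and the only readable step therefore has no partner to be compared with: the limit of > 100000 nM in this assay, at which 2 of the 4 values shown sit. This shows that the change is tolerated within the scatter on one core and in one place, but it does not show whether that result carries over to the other core.

The compounds shown leave open what an amine or a carboxylic acid in place of that same hydrogen would give in this assay. They also leave open whether a longer chain than methoxy, such as propoxy, would move the value on either core beyond the scatter.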